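The compounds below may be only part of what the source reports. "The series", "measured", "known", "first", "only" and "open" are said of these compounds alone.

Compound 1 `CC1(C)Oc2ccc(C#N)cc2[C@@H](NC(=O)NCc2ccccc2)[C@@H]1O`: 5600 nM
Compound 2 `CC1(C)Oc2ccc(C#N)cc2[C@@H](NC(=O)Nc2cccnc2)[C@@H]1O`: 500 nM
Compound 3 `CC1(C)Oc2ccc(C#N)cc2[C@@H](NC(=O)Nc2ccccn2)[C@@H]1O`: 440 nM

In a functional assay (aorta) with Rattus norvegicus as the target (on this read-out higher numbers stand for weaker inhibition and lower numbers for stronger inhibition), compound 3 and compound 2 sit within the scatter of each other, and both stand far from compound 1, as the steps of a 13-fold lower number from compound 1 to compound 3 (1.10 log units; beyond the scatter) and an 11-fold lower number from compound 1 to compound 2 (1.05 log units; beyond the scatter) show. Compound 4 `CC1(C)Oc2ccc(C#N)cc2[C@@H](NC(=O)Nc2ccncc2)[C@@H]1O` differs from compound 3 only by pyridin-4-yl in place of pyridin-2-yl on an amide-type nitrogen. Among the measured compounds shown here, the one step that bears on this is a 1.1-fold lower number from compound 2 to compound 3 (0.06 log units; within the scatter), which lies within the scatter: shifting the ring nitrogen from one position to another changed nothing measurable. A further shift of the same kind is therefore expected to give no step beyond the scatter, so compound 4 is estimated at 500 nM (range 200 nM to 1300 nM), meaning an expected step of a 1.1-fold higher number from compound 3 to compound 4 (0.06 log units; within the scatter).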

Compound 4, half-maximal inhibitory concentration: 8500 nM
Estimate against measurement, compound 4: 17-fold (1.23 log units) below; measured number outside the range, above it.
By their numbers in this assay, from the lowest: compounds 3 and 2 (each within the scatter of the next); then compounds 1 and 4 (each within the scatter of the next).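

On this amide-type nitrogen in this assay the place of the ring nitrogen does matter: the change to pyridin-4-yl gives a 19-fold higher number from compound 3 to compound 4 (1.29 log units; beyond the scatter) and a 17-fold higher number from compound 2 to compound 4 (1.23 log units; beyond the scatter) even though the groups have the same atoms. With a 1.5-fold higher number from compound 1 to compound 4 (0.18 log units; within the scatter) lying within the scatter, pyridin-4-yl keeps none of the advantage that pyridin-2-yl and pyridin-3-yl hold over benzyl. No measurement at hand explains this sharp dependence on ring position.

Left open is where plain phenyl or an aminopyridinyl group would fall on this nitrogen, and so whether pyridin-4-yl is the exception or the other two pyridines are.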